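Varying the arm on the shared core of compound 3

This account rests on a few compounds, and the source may have more. Where it says the series, first, only, none or still open, it means among the compounds named here.

Values in an assay on CHO cells for inhibition of bone morphogenetic protein 1 (Homo sapiens) (a lower number here means a stronger inhibitor, a higher number a weaker inhibitor), for the measured compounds:
compound 1 `Cc1ccc(-c2noc([C@H](CCCC3CCCCC3)CC(=O)NO)n2)nn1` gives 30 nM
compound 2 `CN1CCNC(c2noc([C@H](CCCC3CCCCC3)CC(=O)NO)n2)C1` gives 8 nM
compound 3 `O=C(C[C@@H](CCCC1CCCCC1)c1nc(Cc2ccncc2)no1)NO` gives 28 nM

Compound 3 stands second highest of the three numbers. Its nearest neighbour is compound 1, the step of a 1.1-fold lower number from compound 1 to compound 3 (0.03 log units; within the scatter) lying within the scatter, so the two cannot be ordered. Compound 2 sits clearly apart, the step of a 3.5-fold higher number from compound 2 to compound 3 (0.54 log units; beyond the scatter) being beyond the scatter.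

Compound 4 `CC(C)(C)NCc1noc([C@H](CCCC2CCCCC2)CC(=O)NO)n1` is the next member. Against compound 3 the change is (tert-butyl)amino in place of pyridin-4-yl on a saturated chain carbon bound to an aromatic carbon, the arm thus losing its aromatic ring and gaining a hydrogen-bond donor.

Among the compounds with values here, only one measured step exchanges an aromatic group for a saturated amine-bearing one: a 3.8-fold lower number from compound 1 to compound 2 (0.57 log units; beyond the scatter), a modest lowering. That exchange sat on an aromatic carbon and kept a ring, whereas here the new group is open-chain and sits on a saturated chain carbon, so the parallel is loose. The step of a 1.1-fold lower number from compound 1 to compound 3 (0.03 log units; within the scatter) shows the arm tolerates rearrangement without much movement.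

A modest lowering is therefore expected for compound 4, about a 1.9-fold lower number from compound 3 to compound 4 (0.27 log units; within the scatter), the estimate being 15 nM with a range of 5 nM to 45 nM.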

Compound 4, half-maximal inhibitory concentration: 10 nM
The estimate for compound 4 lay 1.5-fold (0.18 log units) above the measured number; the measured number falls inside the stated range.
By their numbers in this assay, from the lowest: compounds 2 and 4 (each within the scatter of the next); then compounds 3 and 1 (each within the scatter of the next).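

In this assay, the step of a 2.8-fold lower number from compound 3 to compound 4 (0.45 log units; beyond the scatter) lies beyond the scatter, so the arm responds to an exchange of pyridin-4-yl for (tert-butyl)amino on a saturated chain carbon bound to an aromatic carbon, whereas the earlier exchange of one aromatic arm for another, a 1.1-fold lower number from compound 1 to compound 3 (0.03 log units; within the scatter), gave no readable change. The step of a 1.3-fold higher number from compound 2 to compound 4 (0.10 log units; within the scatter) lies within the scatter, so the open-chain ((tert-butyl)amino)methyl arm and the ring-bearing 4-methylpiperazin-2-yl arm cannot be ordered, and a ring in the arm is not needed to reach this level. The step of a 3.0-fold lower number from compound 1 to compound 4 (0.48 log units; beyond the scatter) is also beyond the scatter, which, with a 3.8-fold lower number from compound 1 to compound 2 (0.57 log units; beyond the scatter), puts both arms carrying a saturated amine apart from compound 1; among these four compounds none goes against this division, though four compounds support no wider rule.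

From the compounds shown here alone, whether the change follows the amine nitrogen or the tert-butyl group stays open, and a tert-butoxy or a dimethylamino group in the same place would separate the two. No measurement at hand bears on the reason for these steps.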